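This account rests on a few compounds, and the source may have more. Where it says the series, first, only, none or still open, it means among the compounds named here.

In an ADME assay on Vero cells (Chlorocebus sabaeus) for cytotoxicity, read by MTT assay, with a stated time of 72 h (on this read-out lower numbers stand for higher toxicity in this test and higher numbers for lower toxicity in this test), three compounds built on one shared core have been examined. Compound 1 `COC(=O)c1cc(-c2cccc(NC(=O)c3ccc(/C=C/C(=O)c4ccc(F)cc4F)cc3)c2)on1` returns only a limit, > 40 ug/mL, not a number. Compound 2 `COC(=O)c1cc(-c2cccc(NC(=O)c3ccc(/C=C/C(=O)c4ccccc4OC)cc3)c2)on1` likewise returns only a limit, > 40 ug/mL. Compound 3 `COC(=O)c1cc(-c2cccc(NC(=O)c3ccc(/C=C/C(=O)c4ccccc4Cl)cc3)c2)on1` also returns only a limit, > 25 ug/mL. Compound 3 thus stands at the limit of > 25 ug/mL in this assay, at which 1 of the 3 values shown sits, while the other two stand at the limit of > 40 ug/mL in this assay, at which 2 of the 3 values shown sit. Going by the values given here, the measured steps a step that the two limits leave unreadable from compound 1 to compound 2, a step that the two limits leave unreadable from compound 1 to compound 3 and a step that the two limits leave unreadable from compound 2 to compound 3 are all of unreadable size, each end being a limit, so no step among the measured compounds can be sized.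

Compound 4 `COC(=O)c1cc(-c2cccc(NC(=O)c3ccc(/C=C/C(=O)c4ccc([N+](=O)[O-])cc4)cc3)c2)on1` is the next compound, and it differs from compound 3 in one place: 4-nitrophenyl in place of 2-chlorophenyl on a carbonyl carbon. All three measured steps change the same carbonyl-bound ring, so they bear on this change, yet none of them can be read. On that footing no step beyond the usual scatter is expected, and another limit seems the most likely outcome. Compound 4 is therefore estimated at 40 ug/mL, with a range from 20 ug/mL to 80 ug/mL, which would mean an expected step that the limit leaves unreadable from compound 3 to compound 4.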

Compound 4, half-maximal cytotoxic concentration: > 20 ug/mL
Compound 4 ended at the assay's limit; the forecaster's own chance of this, stated with the estimate: 70%; the middle value lies beyond the limit too.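

Compound 4 gives > 20 ug/mL in this assay as a limit, not a number. Its steps from compound 1, compound 2 and compound 3 therefore cannot be read. The compounds shown leave open whether changing the carbonyl-bound ring alters cytotoxicity at all.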